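Removing the Oxazole Methyl: What Clearance to Expect

A few compounds are considered here, and "the series" means these few. Any claim that something is new, unique, unknown or untested is made for them only; others in the source may bear on it.

Compound 1 `Cc1cc2c(cc1Cc1ccc(-c3cocn3)cc1)C(=O)N([C@H]1CCOC[C@@H]1O)C2` and compound 2 `Cc1nc(-c2ccc(Cc3cc4c(cc3C)CN([C@H]3CCOC[C@@H]3O)C4=O)cc2)co1` differ in a single place: hydrogen in place of methyl on an aromatic carbon. In an ADME assay on microsomes from liver (Homo sapiens) for metabolic stability (a higher number here means faster removal of the compound, a lower number slower removal), compound 2 gives 13 mL/min/kg. In this assay compound 1 gives < 8 mL/min/kg, which is a limit of the assay and not a number. The measured step is therefore an at least 1.6-fold lower number from compound 2 to compound 1 (0.21 log units; that floor lies within the scatter).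

Compound 3 `Cc1nc(-c2ccc(Cc3cc4c(cc3C)CCN([C@H]3CCOC[C@@H]3O)C4=O)cc2)co1` carries the same 2-methyl-1,3-oxazol-4-yl group as compound 2 but sits on a different core; the difference between the two cores is not broken down here. In this assay compound 3 gives 21 mL/min/kg, a value that lies within the usual scatter of the number for compound 2, so the two cannot be told apart on this evidence.

Compound 4 `Cc1cc2c(cc1Cc1ccc(-c3cocn3)cc1)C(=O)N([C@H]1CCOC[C@@H]1O)CC2` has not yet been measured. It differs from compound 3 in one place: hydrogen in place of methyl on an aromatic carbon. Among the compounds with values here, this is the same change, at the same place on the same five-membered ring, as the one from compound 2 to compound 1. The expected step from compound 3 to compound 4 is a 1.9-fold lower number from compound 3 to compound 4 (0.28 log units; within the scatter), and that expectation rests on compound 2 and compound 1, because the same change gave an at least 1.6-fold lower number from compound 2 to compound 1 (0.21 log units; that floor lies within the scatter). Compound 4 is expected to show about 11 mL/min/kg in this assay. The estimate for compound 4 spans from 6 mL/min/kg to 20 mL/min/kg, and a value reported only as a limit would not be surprising.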

Compound 4, clearance: 13 mL/min/kg
Estimate against measurement, compound 4: 1.2-fold (0.07 log units) below; the measured number falls inside the stated range.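

In this assay, replacing 2-methyl-1,3-oxazol-4-yl with 1,3-oxazol-4-yl on the core of compound 3 gives a 1.6-fold lower number from compound 3 to compound 4 (0.21 log units; within the scatter), so this step alone does not tell the two compounds apart. Two cores are too few to make a rule for the series, and neither step shows on its own that the change has a real effect on the number; set side by side, the two steps read: the same change on two cores in this assay, an at least 1.6-fold lower number (0.21 log units; that floor lies within the scatter) from compound 2 to compound 1 and a 1.6-fold lower number (0.21 log units; within the scatter) from compound 3 to compound 4; the limit leaves it open whether they differ. For compound 1, the reading of < 8 mL/min/kg is a limit of the assay and not a number.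

The compounds shown hold only methyl or hydrogen on the aromatic carbon next to the ring nitrogen and next to the ring oxygen, so it remains open how an ethyl group, a methoxy group or an amine at that place would read in this assay. Within the data shown here, only two cores appear here, so it is also open how the same change from 2-methyl-1,3-oxazol-4-yl to 1,3-oxazol-4-yl would read on a third core.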